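The source may hold more compounds than are shown below. What is called first, only, known or untested is meant among the compounds shown, and "the series" means these compounds.

Two members of the series have been tested so far. In a functional assay on MOLT-4 cells (Homo sapiens) for inhibition, read by sulforhodamine B assay, with a stated time of 48 h (a higher number here means a weaker inhibitor of growth, a lower number a stronger inhibitor of growth), compound 1 `COc1cc(-c2cc(/C=C/C(=O)c3ccc(Cl)c(Cl)c3)[nH]n2)cc(OC)c1OC` gives 40600 nM, the higher of the two values, while compound 2 `COc1ccc(-c2cc(/C=C/C(=O)c3ccc(N)cc3)[nH]n2)cc1OC` gives 16500 nM, a gap beyond the scatter. Compound 3 `COc1ccc(C(=O)/C=C/c2cc(-c3cc(OC)c(OC)c(OC)c3)n[nH]2)cc1OC` awaits testing in this assay. It differs from compound 1 at one place: 3,4-dimethoxyphenyl in place of 3,4-dichlorophenyl on a carbonyl carbon. Going by the values given here, no step between measured compounds isolates this change, so compound 2 offers only loose guidance. The expected step from compound 1 to compound 3 in this assay is a 1.6-fold lower number from compound 1 to compound 3 (0.21 log units; within the scatter), a small shift toward a lower number, barely outside the scatter if at all. Compound 3 is accordingly estimated at 25000 nM, with a range of 8000 nM to 70000 nM.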

Compound 3, concentration for total growth inhibition: 5560 nM
The estimate for compound 3 lay 4.5-fold (0.65 log units) above the measured number; the whole stated range lies above it.
By their numbers in this assay, from the lowest: compound 3; then compound 2; then compound 1.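

Going by these compounds alone, on a carbonyl carbon, 3,4-dimethoxyphenyl in place of 3,4-dichlorophenyl gives a 7.3-fold lower number from compound 1 to compound 3 (0.86 log units; beyond the scatter) in this assay, the first single-place step. This position can therefore shift the number beyond the scatter while the rest of compound 1 stays unchanged. No measurement at hand bears on what lies behind this step. Open, going by these compounds, is whether the step follows the methoxy groups or the loss of chlorine. A 3,4-dihydroxyphenyl group at the same carbonyl carbon, on the core of compound 1, would test this.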